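The source may hold more compounds than are shown below. What is called first, only, known or untested is meant among the compounds shown, and "the series" means these compounds.

Of the compounds shown here, two have been measured in an assay on isolated protein for inhibition of Rho-associated protein kinase 2 (Homo sapiens), read by ELISA, with a stated time of 30 min, tested at 10 uM, in the presence of a further agent that is not named here; a lower number here means less inhibition, a higher number more inhibition at the concentration tested (going by the name of the read-out). Compound 1, `CN1CCN(Cc2sc(NC(=O)c3cccnc3)nc2-c2cccnc2)CC1`, gives 32.1% in this assay. Compound 2, `O=C(Nc1nc(-c2cccnc2)c(CN2CCCC2)s1)C1COc2ccccc2O1`, gives 61.3% in this assay, the higher of the two numbers; compound 1 sits below it by a gap that lies beyond the usual scatter. Among the measured compounds shown here, no step between measured compounds that differ in a single place is available, so nothing is yet known about how single changes move the read-out.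

Compound 3, `CN(C)Cc1sc(NC(=O)C2COc3ccccc3O2)nc1-c1cccnc1`, is the next to be measured in this assay. It differs from compound 2 in one place: dimethylamino in place of pyrrolidin-1-yl on a saturated chain carbon bound to an aromatic carbon. The change is confined to the amine on the saturated chain carbon and the rest of compound 2 is kept, so a small step, if any, is expected, most likely downward or none beyond the scatter. The expected step is a number 7.3 percentage points lower from compound 2 to compound 3 (within the scatter). For compound 3 the estimate in this assay is 54%, with a range from 34% to 74%.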

Compound 3, a percentage reported as inhibition, at one concentration (the size of the read-out at that concentration, not a potency): 58.1%
Estimate against measurement, compound 3: 4.1 percentage points below, within the range that was stated.
By their numbers in this assay, from the lowest: compound 1; then compounds 3 and 2 (each within the scatter of the next).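

Among the compounds shown here, the first single-place step, dimethylamino in place of pyrrolidin-1-yl on a saturated chain carbon bound to an aromatic carbon, reads in this assay as a number 3.2 percentage points lower from compound 2 to compound 3 (within the scatter) and so stays within the scatter. For this pair, the five-membered non-aromatic ring of the amine can be exchanged for an open dimethylamino group, with two fewer heavy atoms, without a step beyond the scatter. No accompanying data bear on the reason for this result.

On these data alone, whether a morpholin-4-yl group, a primary amine or a longer chain carrying the amine would leave the read-out as unchanged at this position remains open. The step is also read at a single concentration, so it says nothing about potency.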